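The source may report more compounds than this note shows. Statements on the series, on what has been measured and on what is new or still open speak of the compounds shown alone.

Compound 1 `COc1cc(/C=C\c2ccc(C(C)(C)C)cc2)cc(OC)c1OC`: 4.32 uM
Compound 2 `COc1cc(/C=C/c2ccc(C(C)(C)C)cc2)cc(OC)c1OC`: > 25 uM

Among the measured compounds shown here, in a functional assay on MLM cells (Homo sapiens) for cytotoxicity, using microsomes (on this read-out higher numbers stand for an effect only at larger amounts of compound and lower numbers for an effect already at smaller amounts), compound 1 gives 4.32 uM, the only exact number so far. Compound 2 gives > 25 uM, which is a limit of the assay and not a number. For the measured compounds named here, the only measured step is an at least 5.7-fold higher number from compound 1 to compound 2 (0.76 log units; beyond the scatter), and it goes with the fact that compounds 1 and 2 differ only in the configuration as drawn.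

Compound 3 `CCCOc1ccc(/C=C\c2cc(OC)c(OC)c(OC)c2)cc1` changes something else: propoxy in place of tert-butyl on an aromatic carbon, with propoxy in place of tert-butyl on an aromatic carbon. Its double bond stays drawn Z, as in compound 1 at 4.32 uM, so the measured step does not apply to it. Going by the values given here, no measured step touches this group, which leaves the direction open and the range wide. The expected change is small, with an estimated step of a 1.4-fold lower number from compound 1 to compound 3 (0.16 log units; within the scatter). For compound 3 the estimated value is 3 uM, expected to fall between 0.5 uM and 15 uM.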

Compound 3, concentration for half-maximal effect: 6.5 uM
Estimate against measurement, compound 3: 2.2-fold (0.34 log units) below; the measured number falls inside the stated range.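

Replacing tert-butyl with propoxy at this place, on an aromatic carbon para to a large group, gives a 1.5-fold higher number from compound 1 to compound 3 (0.18 log units; within the scatter) in this assay. Among the compounds shown here, until now the only measured step concerned the drawn shape of the double bond, so this is the first sign that the group on this ring can change, here to one containing oxygen, without moving the number beyond the scatter. Nothing measured here explains why these two groups read alike.

Going by these compounds, whether the same holds for an amine, a carboxylic acid or a longer chain at this place remains open. On these data alone, it is also open whether propoxy would show the same gap between the Z and E forms of the double bond that separates compound 1 from compound 2.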